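Methoxy Added to the Phenyl Ring of Compound 2

The source may report more compounds than this note shows. Statements on the series, on what has been measured and on what is new or still open speak of the compounds shown alone.

Within the data shown here, in a functional assay on HeLa cells (Homo sapiens) for antiproliferative activity, read by MTT assay, with a stated time of 48 h, in the presence of a further agent that is not named here (on this read-out lower numbers stand for stronger inhibition of growth and higher numbers for weaker inhibition of growth), compound 2 `O=C(NOCc1ccc(Cl)cc1Cl)c1cn(-c2ccccc2)nc1-c1ccccc1` gives 5100 nM, the lowest of the two numbers so far. Among the measured compounds shown here, compound 1 `O=C(NOCc1ccccc1F)c1cn(-c2ccccc2)nc1-c1ccccc1` gives 11800 nM in this assay, and the only measured step, a 2.3-fold lower number from compound 1 to compound 2 (0.36 log units; beyond the scatter), changed the ring on the saturated chain carbon bound to an oxygen. For the measured compounds named here, compound 3 `COc1ccc(-c2nn(-c3ccccc3)cc2C(=O)NOCc2ccc(Cl)cc2Cl)cc1` differs from compound 2 by methoxy in place of hydrogen on an aromatic carbon, a ring no measured step has touched, so no step bears directly on it. Compound 3 is therefore expected to stay within the scatter, with a step of a 1.1-fold lower number from compound 2 to compound 3 (0.05 log units; within the scatter). Compound 3 is estimated at 4500 nM, between 1800 nM and 12000 nM.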

Compound 3, concentration for 50% growth inhibition: 5750 nM
For compound 3 the middle estimate is 1.3-fold (0.11 log units) below the measured one, within the range that was stated.
By their numbers in this assay, from the lowest: compounds 2 and 3 (each within the scatter of the next); then compound 1.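

In this assay, phenyl to 4-methoxyphenyl gives a 1.1-fold higher number from compound 2 to compound 3 (0.05 log units; within the scatter), so methoxy is tolerated on this aromatic carbon, para to a large group, at least with the 2,4-dichlorophenyl group in place. Among these compounds, this is the first measured step on this ring, since the earlier step changed only the ring on the saturated chain carbon bound to an oxygen. Nothing available explains this result.

As far as these compounds go, whether an amine or a carboxylic acid would be tolerated on the same carbon remains open. So does whether a longer chain on the oxygen in place of methyl would be.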